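Reversing an Amide on a Shared Agonist Core

The compounds below may be only part of what the source reports. "The series", "measured", "known", "first", "only" and "open" are said of these compounds alone.

Compound 1 `CNc1nc(NCc2ccc(NC(C)=O)cc2)cc(-c2ccccn2)n1` — 2 nM
Compound 2 `CNc1nc(NCC2CCCCC2)cc(-c2ccccn2)n1` — 10 nM
Compound 3 `CNc1nc(NCc2ccc(NC(C)=O)cc2F)cc(-c2ccccn2)n1` — "not determined" (no result reported)

In a functional assay on HEK293 cells for agonist activity at G-protein coupled receptor 39 (Mus musculus), read by inositol phosphate accumulation (on this read-out higher numbers stand for an effect only at larger amounts of compound and lower numbers for an effect already at smaller amounts), compound 1 gives 2 nM, the lowest of the two numbers reported. Compound 2 gives 10 nM, a higher number that lies beyond the usual scatter. For compound 3 the entry in this assay reads "not determined" (no result reported). Compound 4 `CNC(=O)c1ccc(CNc2cc(-c3ccccn3)nc(NC)n2)cc1` keeps the same atoms as compound 1, joined differently: methylcarbamoyl in place of acetamido on an aromatic carbon. Among the compounds with values here, no measured pair covers a change of this kind, so the expectation rests on compound 1 alone, with the same hydrogen-bond donor and acceptor count retained. Expected is a small shift, if any, with a slight lean toward a higher number, a 2.0-fold higher number from compound 1 to compound 4 (0.30 log units; within the scatter). Compound 4 is therefore estimated at 4 nM, within a range from 1.5 nM to 15 nM.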

Compound 4, half-maximal effective concentration: 8 nM
For compound 4 the middle estimate is 2.0-fold (0.30 log units) below the measured one; measured number inside the range.
By their numbers in this assay, from the lowest: compound 1; then compounds 4 and 2 (each within the scatter of the next).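

Reversing the amide at this place, on an aromatic carbon para to a large group, is not a silent swap in this assay: methylcarbamoyl in place of acetamido gives a 4.0-fold higher number from compound 1 to compound 4 (0.60 log units; beyond the scatter), a modest step. The two groups match in every count of atoms, hydrogen-bond donors and acceptors, so only the way they are joined differs. Nothing in the data shown accounts for this step.

Open, going by these compounds, is how other groups at this place, such as a carboxylic acid, an amine or a longer chain, would compare with acetamido.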